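The source may hold more compounds than are shown below. What is called first, only, known or untested is meant among the compounds shown, and "the series" means these compounds.

Series notes. The shared core is carried by compound 1 `CS(=O)(=O)c1ccc(C(=O)NCCC(=O)N2CCCCC2)cc1[N+](=O)[O-]`, compound 2 `CS(=O)(=O)c1ccc(C(=O)NCCC(=O)N2CCc3ccccc32)cc1[N+](=O)[O-]` and compound 3 `CC1CCN(C(=O)CCNC(=O)c2ccc(S(C)(=O)=O)c([N+](=O)[O-])c2)CC1`, which differ only in the group on the carbonyl carbon of the chain. In an assay on isolated protein for inhibition of thyroid hormone receptor beta (Homo sapiens), read by fluorescence polarization (on this read-out higher numbers stand for weaker inhibition and lower numbers for stronger inhibition), compound 1 gives > 60000 nM, a limit of the assay and not a number. In this assay compound 2 gives > 60000 nM, likewise a limit. Compound 3 stands at > 60000 nM in this assay, again a limit. Within the data shown here, because all three values sit at the limit of > 60000 nM in this assay, at which 3 of the 3 values shown sit, none of the measured steps can be read: a step that the two limits leave unreadable from compound 1 to compound 2, a step that the two limits leave unreadable from compound 1 to compound 3 and a step that the two limits leave unreadable from compound 2 to compound 3. Compound 3 therefore stands with the other two at the limit, with no readable order among them.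

Compound 4 `CC(C)N(C(=O)CCNC(=O)c1ccc(S(C)(=O)=O)c([N+](=O)[O-])c1)C(C)C` differs from compound 3 in one place: diisopropylamino in place of 4-methylpiperidin-1-yl on a carbonyl carbon. Among the measured compounds shown here, the steps that bear on this change are the three unreadable ones above, which show only that each earlier exchange of the group on the carbonyl carbon left every compound at the limit; no size can be taken from them. The expectation is that compound 4 will also be reported as a limit, so the estimated step that the limit leaves unreadable from compound 3 to compound 4 is set as none beyond the scatter. Compound 4 is estimated at 80000 nM in this assay, within 30000 nM to 250000 nM.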

Compound 4, half-maximal inhibitory concentration: > 60000 nM
Compound 4 gave a limit, no number; the forecaster's own chance of this, stated with the estimate: 85%; the middle value is on the limit's open side.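

Compound 4 sits at the limit of the assay in this assay together with compound 1, compound 2 and compound 3, so no step from or to compound 4 can be read: the limit of > 60000 nM in this assay, at which 4 of the 4 values shown sit.

The compounds shown leave open what order these four hold in this assay, and whether any group on the carbonyl carbon gives a value that is a number.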